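Replacing the Sulfonamide Arm with a Diethylamide

A few compounds are considered here, and "the series" means these few. Any claim that something is new, unique, unknown or untested is made for them only; others in the source may bear on it.

Three compounds sharing one core differ only in the group on a sulfonamide nitrogen. In a functional assay on MIA PaCa-2 cells (Homo sapiens) for inhibition, read by MTT assay, with a stated time of 7 days (a higher number here means a weaker inhibitor, a lower number a stronger inhibitor), compound 1 `CC(C)c1noc(N2CCN(C(=O)[C@@H]3CCCN(S(=O)(=O)c4ccc(S(=O)(=O)NC5CC5)cc4)C3)CC2)n1` gives 1000 nM, compound 2 `CC(C)c1noc(N2CCN(C(=O)[C@@H]3CCCN(S(=O)(=O)c4ccc(S(=O)(=O)NC(C)(C)C)cc4)C3)CC2)n1` gives 300 nM, and compound 3 `CCNS(=O)(=O)c1ccc(S(=O)(=O)N2CCC[C@@H](C(=O)N3CCN(c4nc(C(C)C)no4)CC3)C2)cc1` gives 3300 nM. Compound 3 stands highest of the three, and both steps into it go beyond the scatter: a 3.3-fold higher number from compound 1 to compound 3 (0.52 log units; beyond the scatter) and an 11-fold higher number from compound 2 to compound 3 (1.04 log units; beyond the scatter); the step of a 3.3-fold lower number from compound 1 to compound 2 (0.52 log units; beyond the scatter) completes the picture, with the bulkiest alkyl giving the lowest number.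

Compound 4 `CCN(CC)C(=O)c1ccc(S(=O)(=O)N2CCC[C@@H](C(=O)N3CCN(c4nc(C(C)C)no4)CC3)C2)cc1` departs from compound 3 in a different way: diethylcarbamoyl in place of ethylsulfamoyl on an aromatic carbon. Within the data shown here, no measured step changes the sulfonamide itself, so the three steps above bear on this change only loosely; they show that the group in this position shifts the number by modest to large amounts in either direction. Among the measured compounds shown here, the loss of the hydrogen-bond donor and the added carbon have no measured counterpart here. On that basis, compound 4 is expected to land near compound 3, with the uncertainty spanning modest change in either direction, expressed as a 1.3-fold lower number from compound 3 to compound 4 (0.12 log units; within the scatter). The estimate for compound 4 in this assay is 2500 nM, between 600 nM and 10000 nM.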

Compound 4, half-maximal inhibitory concentration: 100 nM
Beside the measured number, compound 4's estimate is 25-fold (1.40 log units) above it; the measured number lies below the stated range.
By their numbers in this assay, from the lowest: compound 4; then compound 2; then compound 1; then compound 3.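

In this assay, the change on this aromatic carbon, para to a large group, produces the largest step shown: a 33-fold lower number from compound 3 to compound 4 (1.52 log units; beyond the scatter). It also carries the series past both sulfonamides that had stood lower than compound 3, with a 3.0-fold lower number from compound 2 to compound 4 (0.48 log units; beyond the scatter) and a 10-fold lower number from compound 1 to compound 4 (1.00 log units; beyond the scatter), so the sulfamoyl arm is not needed for a low number here, and the diethylcarbamoyl of compound 4 outdoes even the tert-butyl variant, the best of the sulfonamide nitrogen groups shown. The change swaps several things at once, removing the sulfur and the only hydrogen-bond donor of the arm and adding carbon, and nothing available explains the size of the step or assigns it to any one of these features.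

Going by these compounds, it remains open whether the low number depends on the two ethyl groups, on the carbonyl or on the missing amide hydrogen. An ethylcarbamoyl would test the hydrogen on the same aromatic carbon, a diethylsulfamoyl would test the carbonyl against the sulfonyl, and a dimethylcarbamoyl would test the length of the alkyl chains.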